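This account rests on a few compounds, and the source may have more. Where it says the series, first, only, none or still open, it means among the compounds named here.

Compound 1 `COc1ccc2occ(CSC(=S)N(C(C)C)C(C)C)c(=O)c2c1` gives 5400 nM in a functional assay on HeLa cells (Homo sapiens) for antiproliferative activity, read by MTT assay, with a stated time of 72 h (a higher number here means a weaker inhibitor, a lower number a stronger inhibitor), the lowest of the two numbers shown. Compound 2 `CCN(CC)C(=S)SCc1cc(=O)c2ccc(Cl)cc2o1` gives 8700 nM in this assay, which lies within the scatter of the value of compound 1, so the two cannot be ranked. Compound 3 `CC(C)N(C(=S)SCc1coc2ccccc2c1=O)C(C)C` reaches only a limit in this assay, > 30000 nM, and no number is known for it; this is the limit of > 30000 nM in this assay, at which 1 of the 3 values shown sits. Within the data shown here, the one measured step that starts from compound 1 is an at least 5.5-fold higher number from compound 1 to compound 3 (0.74 log units; beyond the scatter), and it concerns the methoxy, not the amine part.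

Compound 4 `COc1ccc2occ(CSC(=S)N3CCCCC3)c(=O)c2c1` carries piperidin-1-yl in place of diisopropylamino on a thiocarbonyl carbon. Among the measured compounds shown here, no measured step changes the amine on the thiocarbonyl carbon alone; compound 2 differs from compound 1 in the amine but also elsewhere, and its value sits within the scatter of compound 1. The expected step in this assay is therefore none beyond the scatter, with no change at the digits printed from compound 1 to compound 4 (within the scatter). Compound 4 is estimated to give 5400 nM, within a range of 2500 nM to 12000 nM.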

Compound 4, half-maximal inhibitory concentration: 3500 nM
Estimate against measurement, compound 4: 1.5-fold (0.19 log units) above, within the range that was stated.
By their numbers in this assay, from the lowest: compounds 4, 1 and 2 (each within the scatter of the next, the first and the last beyond it). At a limit, above all of these: compound 3.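

Piperidin-1-yl in place of diisopropylamino on the thiocarbonyl carbon is the one step shown that alters the amine alone, and it gives a 1.5-fold lower number from compound 1 to compound 4 (0.19 log units; within the scatter) in this assay on the shared core. The two amines therefore cannot be told apart in this read-out, so a ring can stand here in place of the open diisopropylamino group without a change beyond the scatter, whereas the other step shown, hydrogen in place of methoxy, gives an at least 5.5-fold higher number from compound 1 to compound 3 (0.74 log units; beyond the scatter) and does lie beyond it. Nothing measured here gives a cause for the result on the amine.

Going by these compounds, whether a pyrrolidine ring, or a morpholine or piperazine ring with its second hetero atom, would also stay within the scatter of compound 1 remains open. So does whether piperidin-1-yl would hold its value with hydrogen in place of the methoxy.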